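A few compounds are considered here, and "the series" means these few. Any claim that something is new, unique, unknown or untested is made for them only; others in the source may bear on it.

Of the compounds shown here, three have so far been tested in a functional assay on K562 cells (Homo sapiens) for inhibition, read by CCK-8 assay, with a stated time of 72 h; on this read-out higher numbers stand for weaker inhibition and lower numbers for stronger inhibition. Compound 1 `O=C(/C=C/c1cccnc1)NCCCCCc1ccc(S(=O)(=O)Nc2ccccc2)cc1` gives 146 nM, compound 2 `O=C(/C=C/c1cccnc1)NCCCCCCc1ccc(S(=O)(=O)Nc2ccccc2)cc1` gives 48.5 nM, and compound 3 `Cc1cccc(NS(=O)(=O)c2cccc(CCCCCCNC(=O)/C=C/c3cccnc3)c2)c1` gives 4.78 nM. Compound 3 therefore has the lowest number of the three, and its gap to each of the others lies beyond the usual scatter of repeated measurements, making it the strongest inhibitor so far. Compound 4 `O=C(/C=C/c1cccnc1)NCCCCCCc1cccc(S(=O)(=O)Nc2ccc(Cl)cc2)c1` matches compound 3 except for one group, with 4-chlorophenyl in place of 3-methylphenyl on a sulfonamide nitrogen. For the measured compounds named here, no measured pair shows this swap on its own, so any forecast remains loose. Compound 3, at 4.78 nM, already has the lowest number here, so a small rise seems more likely than a further fall. The expected change in this assay is a 1.7-fold higher number from compound 3 to compound 4 (0.22 log units; within the scatter), a slight move toward weaker inhibition that stays within the scatter. For compound 4 the estimated value is 8 nM, with an expected range from 2.5 nM to 25 nM.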

Compound 4, half-maximal inhibitory concentration: 6.41 nM
Beside the measured number, compound 4's estimate is 1.2-fold (0.10 log units) above it; measured number inside the range.
By their numbers in this assay, from the lowest: compounds 3 and 4 (each within the scatter of the next); then compound 2; then compound 1.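

In this assay, for the compounds shown here, the swap on the sulfonamide nitrogen gives a 1.3-fold higher number from compound 3 to compound 4 (0.13 log units; within the scatter), the first comparison here between two compounds that differ in one place. At this position, 4-chlorophenyl can therefore take the place of 3-methylphenyl with no difference that stands out from the scatter, so this pair shows that a methyl-bearing ring and a chlorine-bearing ring of the same size can give values that cannot be told apart. Nothing available here explains why the two groups read alike.

This single swap changes both the atom on the ring and where it sits, so 3-chlorophenyl and 4-methylphenyl would be needed to separate those two changes. Going by these compounds, how a 4-methoxyphenyl group or a ring carrying a carboxylic acid would behave on this nitrogen also remains open.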